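Cyclohexyl in place of 4-methoxyphenyl on the amine nitrogen

The compounds below may be only part of what the source reports. "The series", "measured", "known", "first", "only" and "open" are said of these compounds alone.

In a functional assay on HeLa cells (Homo sapiens) for inhibition, read by sulforhodamine B assay (a lower number here means a stronger inhibitor, a higher number a weaker inhibitor), compound 1 `O=C1C(Nc2ccccc2F)=CC(=O)c2c1nc1n2[C@H]2OC[C@@H](O)[C@H]2OC1` gives 9820 nM. Compound 2 `COc1ccc(NC2=CC(=O)c3c(nc4n3[C@H]3OC[C@@H](O)[C@H]3OC4)C2=O)cc1` returns only a limit, > 8000 nM, and has no exact value. Within the data shown here, the one measured step that bears on the next change, a step that the limit leaves unreadable from compound 1 to compound 2, therefore offers no size to carry forward.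

Compound 3 `O=C1C(NC2CCCCC2)=CC(=O)c2c1nc1n2[C@H]2OC[C@@H](O)[C@H]2OC1` has cyclohexyl in place of 4-methoxyphenyl on an amine nitrogen. Among the measured compounds shown here, no measured compound here carries a non-aromatic ring at this place, so the data favour neither direction. For the measured compounds named here, the only exact number is that of compound 1 at 9820 nM, and the expectation stays close to it, with no change beyond the scatter in this assay. The expected step is a step that the limit leaves unreadable from compound 2 to compound 3. For compound 3 the estimated value is 9000 nM, with an expected range from 3500 nM to 25000 nM.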

Compound 3, half-maximal inhibitory concentration: > 16000 nM
Compound 3 was reported as a limit; the forecaster's own chance of this, stated with the estimate: 45%; middle value at least 1.7-fold (0.24 log units) from the limit.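

In this assay compound 3 is reported only as a limit, > 16000 nM. Set against the one exact value, cyclohexyl in place of 2-fluorophenyl on the amine nitrogen reads as an at least 1.6-fold higher number from compound 1 to compound 3 (0.21 log units; that floor lies within the scatter), so this first non-aromatic ring at the position brings no gain over the 2-fluorophenyl group, while the true size of the step remains unknown. The steps that involve compound 2 cannot be read, so the cyclohexyl and 4-methoxyphenyl groups cannot be ranked against each other.

From the compounds shown here alone, whether a non-aromatic ring truly differs from an aromatic one at this place remains open, since no exact value exists for either compound 2 or compound 3. Also open, going by these compounds, is how an open chain such as n-butyl, or a chain ending in an amine or a carboxylic acid, would read on this amine nitrogen in this assay.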